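This account rests on a few compounds, and the source may have more. Where it says the series, first, only, none or still open, it means among the compounds named here.

Compound 1 `O=C1O[C@H]([C@@H](O)Cn2cc(-c3ccc(Br)cc3)nn2)C(OCc2ccccc2)=C1OCc1ccccc1`: 3760 nM
Compound 2 `O=C1O/C(=C\Cn2cc(-c3cc(C(F)(F)F)cc(C(F)(F)F)c3)nn2)C(OCc2ccccc2)=C1OCc1ccccc1`: > 100000 nM
Compound 3 `COc1ccc(-c2cn(C/C=C3\OC(=O)C(OCc4ccccc4)=C3OCc3ccccc3)nn2)cc1`: > 100000 nM

For the measured compounds named here, in a functional assay on SW-620 cells (Homo sapiens) for antiproliferative activity, read by MTT assay, with a stated time of 72 h (a lower number here means a stronger inhibitor, a higher number a weaker inhibitor), compound 1 gives 3760 nM, the only number in the set. For compound 2 the reported value > 100000 nM is a limit of the assay, not a number. For compound 3 the reported value > 100000 nM is likewise a limit. Compound 1 therefore stands alone as the single measurable point, given (the limit of > 100000 nM in this assay, at which 2 of the 3 values shown sit).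

Compound 4 `O=C1O[C@H]([C@@H](O)Cn2cc(CNS(=O)(=O)c3ccc(F)cc3)nn2)C(OCc2ccccc2)=C1OCc1ccccc1` differs from compound 1 by (((4-fluorophenyl)sulfonyl)amino)methyl in place of 4-bromophenyl on an aromatic carbon. Going by the values given here, no measured pair in the set carries a change of this kind, so the step has no anchor. A modest loss, or none beyond the scatter, is expected for a 1.9-fold higher number from compound 1 to compound 4 (0.27 log units; within the scatter). Compound 4 is expected to give about 7000 nM, within 2000 nM to 30000 nM.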

Compound 4, half-maximal inhibitory concentration: 41100 nM
Beside the measured number, compound 4's estimate is 5.9-fold (0.77 log units) below it, outside the stated range (above it).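

At the aromatic carbon of the five-membered aromatic ring with 3 nitrogen, the substituent clearly matters in this assay: (((4-fluorophenyl)sulfonyl)amino)methyl in place of 4-bromophenyl gives an 11-fold higher number from compound 1 to compound 4 (1.04 log units; beyond the scatter). Compound 4 gives 41100 nM as a measured number, so this change lowers activity but still leaves a readable value. No measurement shown accounts for the loss. From the compounds shown here alone, it remains open whether the loss follows the sulfonyl amino link or the exchange of bromine for fluorine, and how an amine or a carboxylic acid on this carbon would read in this assay.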